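The source may hold more compounds than are shown below. What is called first, only, known or untested is meant among the compounds shown, and "the series" means these compounds.

Measured so far in a functional assay on MCF7 cells (Homo sapiens) for inhibition; a higher number here means a weaker inhibitor, a lower number a stronger inhibitor:
- compound 1 `CCCN1C(=O)NC2(CSC3=C2C(=O)c2ccccc2C3=O)C1=O`: 104 nM
- compound 2 `CCC(C)N1C(=O)NC2(CSC3=C2C(=O)c2ccccc2C3=O)C1=O`: 178 nM

Compound 2 holds the higher of the two numbers in this assay, but its nearest neighbour is compound 1 and the gap between them sits within the scatter, so no order can be read from the pair.

The next compound, compound 3 `CCN(CC)CCCN1C(=O)NC2(CSC3=C2C(=O)c2ccccc2C3=O)C1=O`, differs from compound 2 by 3-(diethylamino)propyl in place of sec-butyl on an amide-type nitrogen in a ring. For the measured compounds named here, the only measured step at this position is a 1.7-fold higher number from compound 1 to compound 2 (0.23 log units; within the scatter), which shows that altering the saturated chain on this ring nitrogen moved the number little. Going by the values given here, no measured step adds a nitrogen to the chain, so that part of the change is uncovered by data.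

On that basis the step from compound 2 to compound 3 is expected to be small, a 1.1-fold higher number from compound 2 to compound 3 (0.05 log units; within the scatter), with no direction that can be called beyond the scatter. Compound 3 is therefore estimated at 200 nM, within a range of 60 nM to 700 nM.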

Compound 3, half-maximal inhibitory concentration: 26 nM
Compound 3: the middle estimate sits 7.7-fold (0.89 log units) above what was measured; the whole stated range lies above it.
By their numbers in this assay, from the lowest: compound 3; then compounds 1 and 2 (each within the scatter of the next).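

In this assay, the saturated chain on the amide-type nitrogen in a ring proves less silent than the first pair suggested: a 1.7-fold higher number from compound 1 to compound 2 (0.23 log units; within the scatter) stays within the scatter, whereas 3-(diethylamino)propyl in place of sec-butyl gives a 6.8-fold lower number from compound 2 to compound 3 (0.84 log units; beyond the scatter) and moves the number beyond it. The closest comparison, diethylamino in place of hydrogen on a saturated chain carbon, three bonds along the chain from that nitrogen, gives a 4.0-fold lower number from compound 1 to compound 3 (0.60 log units; beyond the scatter) and ties the shift to the added amine on the propyl chain rather than to branching of the alkyl group. No evidence here bears on what lies behind this shift.

Open, from the compounds shown here alone, is whether a shorter or longer chain carrying the same diethylamino group would keep the lower number. Also open, going by these compounds, is whether a smaller amine such as dimethylamino, a ring amine such as pyrrolidine or a carboxylic acid at the chain end would behave alike.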